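Changing the Amide Nitrogen Substituent: From Isopropyl to Morpholine

The source may report more compounds than this note shows. Statements on the series, on what has been measured and on what is new or still open speak of the compounds shown alone.

Of the compounds shown here, three sharing one core have been tested in a functional assay on the whole organism (strain Wistar) for inhibition, with Rattus norvegicus as the target, read by paw edema, with stated times of 60 min and 24 h, at a dose of 100 mg/kg by the oral route; on this read-out higher numbers stand for more inhibition at the one dose given (going by the name of the read-out) and lower numbers for less inhibition. Compound 1 `COc1cc2c(cc1OC)C(CC(=O)NC(C)C)CC2` gives 30%, the lowest of the three numbers. Compound 2 `CCCCCNC(=O)CC1CCc2cc(OC)c(OC)cc21` gives 46.7%, and compound 3 `COc1cc2c(cc1OC)C(CC(=O)NC1CCCC1)CC2` gives 46.7%. The step of a number 16.7 percentage points higher from compound 1 to compound 2 (beyond the scatter) and the step of a number 16.7 percentage points higher from compound 1 to compound 3 (beyond the scatter) were both modest rises, while no change at the digits printed from compound 2 to compound 3 (within the scatter). Compound 4 `COc1cc2c(cc1OC)C(CC(=O)N1CCOCC1)CC2` differs from compound 1 by morpholin-4-yl in place of isopropylamino on a carbonyl carbon. Among the compounds with values here, no measured step removes the amide hydrogen, so the two earlier steps bear only loosely on this one: each put a larger group on the nitrogen and raised the number. A similar modest rise is therefore expected, with wide uncertainty, so compound 4 is estimated at 40%, ranging from 20% to 60%, which means an expected step of a number 10 percentage points higher from compound 1 to compound 4 (within the scatter).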

Compound 4, a percentage reported as inhibition, in the whole organism at one dose (the size of the read-out at that dose, not a potency): 23.3%
Compound 4: the middle estimate sits 16.7 percentage points above what was measured; the measured number falls inside the stated range.
By their numbers in this assay, from the lowest: compounds 4 and 1 (each within the scatter of the next); then compounds 2 and 3 (each within the scatter of the next).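

A larger group on this carbonyl carbon does not by itself bring a rise: morpholin-4-yl in place of isopropylamino gives a number 6.7 percentage points lower from compound 1 to compound 4 (within the scatter). The same group also falls short of the pentylamino and cyclopentylamino amides, with a number 23.4 percentage points lower from compound 2 to compound 4 (beyond the scatter) and a number 23.4 percentage points lower from compound 3 to compound 4 (beyond the scatter). Nothing measured here explains this result.

The swap removes the amide hydrogen and adds a ring oxygen at once, so the compounds shown cannot separate the two changes. Piperidin-1-yl, which has the ring without its oxygen, would pull them apart.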